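Pyridyl-to-phenyl exchange in a hydroxyphenyl pyridine series

This account rests on a few compounds, and the source may have more. Where it says the series, first, only, none or still open, it means among the compounds named here.

Three compounds are in hand: compound 1 `Oc1cccc(-c2cc(-c3ccccn3)nc(-c3ccccc3Cl)c2)c1`, compound 2 `Oc1ccc(-c2cc(-c3ccccc3)nc(-c3ccc(Cl)cc3)c2)cc1` and compound 3 `Oc1ccc(-c2cc(-c3ccc(Cl)cc3)nc(-c3ccccn3)c2)cc1`. In a functional assay on DU-145 cells (Homo sapiens) for cytotoxicity, read by CCK-8 assay and cell counting, with a stated time of 2 days (a lower number here means a stronger inhibitor, a higher number a weaker inhibitor), compound 1 gives "not determined" (no result reported), so no number stands for it. In this assay compound 2 gives 7270 nM, and compound 3 gives 22500 nM. For the measured compounds named here, the single measured step is a 3.1-fold lower number from compound 3 to compound 2 (0.49 log units; beyond the scatter); the change behind it is phenyl in place of pyridin-2-yl on an aromatic carbon.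

Compound 4 `Oc1cccc(-c2cc(-c3ccccc3)nc(-c3ccccc3Cl)c2)c1` is still to be measured in this assay. It arises from compound 1 by phenyl in place of pyridin-2-yl on an aromatic carbon. Going by the values given here, this is the same kind of change as the one from compound 3 to compound 2, not the same: in compound 1 the place is meta to a 2-chlorophenyl group and meta to a 3-hydroxyphenyl group, whereas in compound 3 it is meta to a 4-chlorophenyl group and meta to a 4-hydroxyphenyl group. Compound 1 and compound 3 have the same atoms, joined differently; the difference between the two cores is not broken down here.

Among the compounds with values here, the only measured step of this kind is a 3.1-fold lower number from compound 3 to compound 2 (0.49 log units; beyond the scatter), a modest lowering, resting on that one pair alone. On these data alone, a lowering of a similar size from compound 1 to compound 4 in this assay is expected; the starting value of compound 1 is unknown. For compound 4 the expected value in this assay is 8000 nM, with 2500 nM to 30000 nM as the likely span. This rests on compound 2, which gives 7270 nM and carries the same phenyl group, while the shifted hydroxyl and chlorine of compound 4 are unmeasured.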

Compound 4, half-maximal inhibitory concentration: 1480 nM
The estimate for compound 4 lay 5.4-fold (0.73 log units) above the measured number; the measured number lies below the stated range.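

No new step can be read from compound 1 to compound 4: in this assay compound 1 gives "not determined" (no result reported) and so offers no number to set against compound 4. The compounds shown leave open how much of the value of compound 4 belongs to phenyl in place of pyridin-2-yl and how much to the placing of the hydroxyl and chlorine. Nothing available bears on a cause for this result.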